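The source may hold more compounds than are shown below. What is called first, only, known or untested is meant among the compounds shown, and "the series" means these compounds.

Measured so far:
compound 1, `CCOC(=O)N1CCN(CCCOc2ccc(-c3c[nH]cn3)cc2)CC1`: in an assay on isolated protein for binding affinity to histamine H2 receptor (Homo sapiens) (on this read-out higher numbers stand for weaker inhibition and lower numbers for stronger inhibition), compound 1 gives 69200 nM
compound 2, `N#Cc1ccc(-c2ccc(OCCCN3CCNCC3)cc2)cc1`: in this assay compound 2 gives 22900 nM

Compound 1 holds the higher of the two numbers; the gap down to compound 2 lies beyond the scatter. Compound 3, `CCOC(=O)N1CCN(CCCOc2ccc(-c3ccncc3)cc2)CC1`, is not yet measured and differs from compound 1 by pyridin-4-yl in place of 1H-imidazol-4-yl on an aromatic carbon. Among the measured compounds shown here, no measured pair shows this change, so its direction rests on nothing measured here; a step toward a higher number, beyond the scatter, is expected for compound 3, a 2.2-fold higher number from compound 1 to compound 3 (0.34 log units; beyond the scatter). Compound 3 is estimated at 150000 nM in this assay, with a range from 40000 nM to 600000 nM.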

Compound 3, inhibition constant: 57500 nM
The estimate for compound 3 lay 2.6-fold (0.42 log units) above the measured number; the range from low to high includes it.
By their numbers in this assay, from the lowest: compound 2; then compounds 3 and 1 (each within the scatter of the next).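

In this assay, pyridin-4-yl in place of 1H-imidazol-4-yl on this aromatic carbon gives a 1.2-fold lower number from compound 1 to compound 3 (0.08 log units; within the scatter) and so does not separate the two groups. At this position, a six-membered aromatic ring with 0 hydrogen-bond donors reads the same within the scatter as a five-membered aromatic ring with 1 hydrogen-bond donor. No supporting data bear on this result. Still open, from the compounds shown here alone, is whether a group such as a carboxylic acid or an amine on this aromatic carbon would move the number beyond the scatter.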